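A few compounds are considered here, and "the series" means these few. Any claim that something is new, unique, unknown or untested is made for them only; others in the source may bear on it.

Measured compounds:
compound 1 `CCN(CC)CCNC(=O)c1ccc(C(CC)(CC)c2ccc(OCC(=O)C(C)(C)C)c(C)c2)n1CC`, 91 nM
compound 2 `CCN(CC)CCCNC(=O)c1ccc(C(CC)(CC)c2ccc(OCC(=O)C(C)(C)C)c(C)c2)n1CC`, 22 nM
compound 3 `C#CCCOC(=O)c1ccc(C(CC)(CC)c2ccc(OCC(=O)C(C)(C)C)c(C)c2)n1CC`, 28800 nM

In an assay on HL-60 cells for agonist activity at vitamin D3 receptor (Homo sapiens), read by microscopy, with a stated time of 96 h (on this read-out higher numbers stand for an effect only at larger amounts of compound and lower numbers for an effect already at smaller amounts), compound 3 stands highest of the three numbers, a 320-fold higher number from compound 1 to compound 3 (2.50 log units; beyond the scatter) and a 1300-fold higher number from compound 2 to compound 3 (3.12 log units; beyond the scatter), both beyond the scatter. Within the two amides, a 4.1-fold lower number from compound 1 to compound 2 (0.62 log units; beyond the scatter).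

Compound 4 `CC[C@@H](C)[C@H](NC(=O)c1ccc(C(CC)(CC)c2ccc(OCC(=O)C(C)(C)C)c(C)c2)n1CC)C(=O)O` is not yet measured. The change from compound 3 to compound 4 is (1-carboxy-2-methylbutyl)amino in place of (but-3-yn-1-yl)oxy on a carbonyl carbon. The two measured steps that bear on it, the steps from compound 1 and compound 2 to compound 3, both replace an amide-type nitrogen bearing a basic chain with the (but-3-yn-1-yl)oxy group, and both were large. Among the compounds with values here, compound 4 reverses the direction of that exchange, restoring a carbonyl-bound nitrogen, but the entering group carries a carboxylic acid and not a diethylamino group, for which no measured step exists. A large step downward from compound 3 is therefore expected, though likely short of the full return to compound 1 or compound 2: a 29-fold lower number from compound 3 to compound 4 (1.46 log units; beyond the scatter). For compound 4 the estimate in this assay is 1000 nM, with a range from 100 nM to 15000 nM.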

Compound 4, half-maximal effective concentration: 10 nM
Beside the measured number, compound 4's estimate is 100-fold (2.00 log units) above it; the measured number lies below the stated range.
By their numbers in this assay, from the lowest: compound 4; then compound 2; then compound 1; then compound 3.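

In this assay, the position on the carbonyl carbon does not need a diethylamino group for a low number: a 2900-fold lower number from compound 3 to compound 4 (3.46 log units; beyond the scatter) is a large step, made by (1-carboxy-2-methylbutyl)amino in place of (but-3-yn-1-yl)oxy. On the amide-type nitrogen, 1-carboxy-2-methylbutyl also goes past both diethylamino chains, with a 2.2-fold lower number from compound 2 to compound 4 (0.34 log units; beyond the scatter) and a 9.1-fold lower number from compound 1 to compound 4 (0.96 log units; beyond the scatter), each step modest but beyond the scatter. No measurement at hand accounts for these steps.

Still open, on these data alone, is how far the step from compound 3 rests on the amide hydrogen and how far on the entering chain, a question that the but-3-yn-1-yl amide would address. Also open, as far as these compounds go, is the share of the carboxylic acid and the two defined stereocentres, which the methyl ester and the opposite stereoisomers would test.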